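Adding a chloro to the benzyl group of compound 2

A few compounds are considered here, and "the series" means these few. Any claim that something is new, unique, unknown or untested is made for them only; others in the source may bear on it.

Compound 1 `CC1=C(C(=O)Nc2ccc(Br)cc2)C(c2ccc(Cl)cc2Cl)N=C(SCc2ccccc2)N1`: 1.5%
Compound 2 `COc1ccc(C2N=C(SCc3ccccc3)NC(C)=C2C(=O)Nc2ccc(Br)cc2)cc1`: 1%

In a functional assay on the whole organism (artery, strain albino) with Rattus norvegicus as the target, with a stated time of 15 min, at a dose of 10 mg/kg by the oral route (on this read-out lower numbers stand for less inhibition and higher numbers for more inhibition at the one dose given (going by the name of the read-out)), compound 2 gives 1%, and compound 1 gives 1.5%. Among the measured compounds shown here, the only measured step, a number 0.5 percentage points lower from compound 1 to compound 2 (within the scatter), shows that these two numbers cannot be told apart; compound 2 stands level with compound 1.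

Compound 3 `COc1ccc(C2N=C(SCc3ccc(Cl)cc3)NC(C)=C2C(=O)Nc2ccc(Br)cc2)cc1` differs from compound 2 by chloro in place of hydrogen on an aromatic carbon. For the measured compounds named here, this place, the benzylsulfanyl arm, is untouched by the one step measured so far, which concerns the group on the saturated ring carbon instead. Going by the values given here, no measured step therefore bears on the change, and both measured compounds show almost no inhibition.

On that basis the step is expected to stay within the scatter: a number 1 percentage points higher from compound 2 to compound 3 (within the scatter). For compound 3 the estimate is 2%, with a range from 0% to 12%.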

Compound 3, a percentage reported as inhibition, in the whole organism at one dose (the size of the read-out at that dose, not a potency): 3.1%
Compound 3: the middle estimate sits 1.1 percentage points below what was measured; the range from low to high includes it.
By their numbers in this assay, from the lowest: compounds 2, 1 and 3 (each within the scatter of the next).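

Compound 2 and compound 3 are the only pair shown that differ on the benzylsulfanyl arm, so this is the one reading of that position. In this assay, chloro in place of hydrogen, para to a large group on the benzyl ring, gives a number 2.1 percentage points higher from compound 2 to compound 3 (within the scatter), so this change cannot be told apart from no change at this dose. Nothing shown alongside these compounds speaks to what lies behind this reading.

The compounds shown leave open whether a different group at this place on the benzyl ring, such as an amine or a carboxylic acid, would move the number beyond the scatter. They also leave open whether a longer chain in place of the benzyl group would do so.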